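Isopropyl to Cyclopropyl: Expected Effect on Inhibition

The source may hold more compounds than are shown below. What is called first, only, known or untested is meant among the compounds shown, and "the series" means these compounds.

Compound 1 `Fc1cc2nc(-c3cncnc3)n(C3CC3)c2cc1F`: 2270 nM
Compound 2 `CC(C)c1ncncc1-c1nc2cc(F)c(F)cc2n1C1CC1`: 1910 nM

In an ADME assay on cells for inhibition of cytochrome P450 11B1, mitochondrial (Homo sapiens), read by HPLC, with a stated time of 60 min (a higher number here means a weaker inhibitor, a lower number a stronger inhibitor), compound 2 gives 1910 nM, and compound 1 gives 2270 nM; the two numbers lie within the scatter of each other, as the step of a 1.2-fold lower number from compound 1 to compound 2 (0.07 log units; within the scatter) shows. Compound 3 `Fc1cc2nc(-c3cncnc3C3CC3)n(C3CC3)c2cc1F` differs from compound 2 in one place: cyclopropyl in place of isopropyl on an aromatic carbon. Within the data shown here, the only measured step touching this carbon is a 1.2-fold lower number from compound 1 to compound 2 (0.07 log units; within the scatter), which was within the scatter. The step of a 1.0-fold lower number from compound 2 to compound 3 (0.00 log units; within the scatter) is therefore expected to stay within the scatter as well. Compound 3 is estimated at 1900 nM, with a range from 950 nM to 3800 nM.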

Compound 3, half-maximal inhibitory concentration: > 10000 nM
Compound 3: only a limit was reported (the forecaster's own chance of this, stated with the estimate: 2%); middle value at least 5.2-fold (0.72 log units) from the limit.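

In this assay this aromatic carbon turns out to respond to the kind of group and not only to its count of heavy atoms: isopropyl and cyclopropyl each hold 3 carbon atoms, yet the change gives an at least 5.2-fold higher number from compound 2 to compound 3 (0.71 log units; beyond the scatter) at this position. Cyclopropyl also separates from hydrogen, with an at least 4.4-fold higher number from compound 1 to compound 3 (0.64 log units; beyond the scatter) in that comparison, whereas the earlier step at this carbon stayed within the scatter. Compound 3 gives > 10000 nM as a limit of the assay, not a number. From the compounds shown here alone, the true size of both steps stays open, as does whether an amine or a longer chain on this carbon would read like isopropyl or like cyclopropyl.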